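Trifluoromethoxy in place of isopropoxy: cytotoxicity outlook

This account rests on a few compounds, and the source may have more. Where it says the series, first, only, none or still open, it means among the compounds named here.

Compound 1, `CC(C)Oc1cccc(-c2ccc(C(=O)N(Cc3cccc(OCCCCCC(=O)O)c3)C(C)C)cc2)c1`: > 26000 nM
Compound 2, `CC(C)N(Cc1cccc(OCCCCCC(=O)O)c1)C(=O)c1ccc(-c2cc3ccccc3n2S(=O)(=O)c2ccccc2)cc1`: > 26000 nM

Both measured compounds were tested in an ADME assay on BJ cells (Homo sapiens) for cytotoxicity, read by CellTiter-Glo and resazurin assay, with a stated time of 72 h; on this read-out lower numbers stand for an effect already at smaller amounts and higher numbers for an effect only at larger amounts of compound. In this assay compound 1 reaches only the limit of the assay, > 26000 nM. Compound 2 likewise stops at the assay limit, > 26000 nM. Neither value is a number, as both sit at the limit of > 26000 nM in this assay, at which 2 of the 2 values shown sit.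

Compound 3, `CC(C)N(Cc1cccc(OCCCCCC(=O)O)c1)C(=O)c1ccc(-c2cccc(OC(F)(F)F)c2)cc1`, has not yet been measured. It differs from compound 1 by trifluoromethyl in place of isopropyl on an oxygen on an aromatic ring.

For the measured compounds named here, no pair of measured compounds differs in a single place, so no measured step shows what such a change does. The step expected here is a number no higher from compound 1 to compound 3 (the limit leaves the size open), none beyond the usual scatter, because compound 1 itself gives only the limit > 26000 nM. Compound 3 is therefore expected to give 26000 nM, within 13000 nM to 60000 nM, most likely again reported only as a limit.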

Compound 3, half-maximal effective concentration: > 26000 nM
Compound 3: a limit, no number (the forecaster's own chance of this, stated with the estimate: 85%); the middle value sits exactly at the limit.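

For the compounds shown here, compound 1 and compound 3 both stop at a limit in this assay, so no step between them can be read: the limit of > 26000 nM in this assay, at which 3 of the 3 values shown sit.

The compounds shown leave open where any of them would reach a half-maximal effect, and whether trifluoromethyl in place of isopropyl alters it.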